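A few compounds are considered here, and "the series" means these few. Any claim that something is new, unique, unknown or untested is made for them only; others in the source may bear on it.

In an ADME assay on L02 cells (Homo sapiens) for cytotoxicity, read by MTT assay, with a stated time of 48 h (a higher number here means a weaker inhibitor, a lower number a stronger inhibitor), compound 1 `CCn1c(C(=O)NCCCN(C)C)ccc1C(CC)(CC)c1ccc(OCC(=O)C(C)(C)C)c(C)c1` gives 670 nM and compound 2 `CCN(CC)CCCNC(=O)c1ccc(C(CC)(CC)c2ccc(OCC(=O)C(C)(C)C)c(C)c2)n1CC` gives 2300 nM, the higher of the two numbers. Among the compounds with values here, the only measured step, a 3.4-fold higher number from compound 1 to compound 2 (0.54 log units; beyond the scatter), comes with diethylamino in place of dimethylamino on a saturated chain carbon. Compound 3 `CCN(CC)CCCNC(=O)c1ccc(C(CC)(CC)c2ccc(OCC(O)C(C)(C)C)c(C)c2)n1CC` keeps that diethylamino group and differs from compound 2 elsewhere: 1-hydroxy-2,2-dimethylpropyl in place of (tert-butyl)carbonyl on a saturated chain carbon bound to an oxygen on an aromatic ring. Here, 1-hydroxy-2,2-dimethylpropyl stands in place of (tert-butyl)carbonyl on a saturated chain carbon bound to an oxygen on an aromatic ring. Within the data shown here, no measured step covers this change, so the modest amine step offers only a rough sense of scale. The expectation therefore rests on compound 2 at 2300 nM, with no change beyond the scatter anticipated. The expected step is a 1.1-fold higher number from compound 2 to compound 3 (0.04 log units; within the scatter). For compound 3, the estimated value is 2500 nM, with an expected range of 1000 nM to 6000 nM.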

Compound 3, half-maximal inhibitory concentration: 2500 nM
Estimate against measurement, compound 3: no gap at the digits printed, and the stated range covers the measured number.
By their numbers in this assay, from the lowest: compound 1; then compounds 2 and 3 (each within the scatter of the next).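

In this assay the change from (tert-butyl)carbonyl to 1-hydroxy-2,2-dimethylpropyl on a saturated chain carbon bound to an oxygen on an aromatic ring gives a 1.1-fold higher number from compound 2 to compound 3 (0.04 log units; within the scatter) and so stays within the scatter, although the entering group carries a hydrogen-bond donor that the leaving group lacks. Within the data shown here, the earlier compounds varied only the amine end of the chain, and this pair is the first to show a change at this other place. Among the steps shown, the only one beyond the scatter remains a 3.4-fold higher number from compound 1 to compound 2 (0.54 log units; beyond the scatter) at the amine end.

On these data alone, it remains open whether an amine, a carboxylic acid or a longer chain at this place would read the same, or whether the same exchange on compound 1 would. Nothing at hand bears on why compound 2 and compound 3 read alike.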